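Cytotoxicity notes on three measured analogues and a pending one

The source may hold more compounds than are shown below. What is called first, only, known or untested is meant among the compounds shown, and "the series" means these compounds.

Measured so far:
Compound 1 `Nc1nc(NC2CCCCC2)c2ncn(/C=C3/CC3(CO)CO)c2n1`: in an ADME assay on HFF cells (Homo sapiens) for cytotoxicity, with a stated time of 8 days (on this read-out higher numbers stand for lower toxicity in this test and lower numbers for higher toxicity in this test), compound 1 gives > 300000 nM, which is a limit of the assay.
Compound 2 `CC(C)CNc1nc(N)nc2c1ncn2/C=C1/CC1(CO)CO`: in this assay compound 2 gives > 300000 nM, a limit of the assay.
Compound 3 `CCCCCCSc1nc(N)nc2c1ncn2/C=C1/CC1(CO)CO`: in this assay compound 3 gives > 300000 nM, a limit of the assay.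

Compound 2 thus stands only at a limit in this assay, as do the other two values shown; this is the limit of > 300000 nM in this assay, at which 3 of the 3 values shown sit. Compound 4 `Nc1nc(NC2CCCC2)c2ncn(/C=C3/CC3(CO)CO)c2n1` is to be measured in this assay and differs from compound 2 in one place: cyclopentyl in place of isobutyl on a nitrogen on an aromatic ring. The nearest measured step is a step that the two limits leave unreadable from compound 1 to compound 2, where cyclohexyl and isobutyl on the same nitrogen are compared and both sides sit at the limit. The steps a step that the two limits leave unreadable from compound 1 to compound 3 and a step that the two limits leave unreadable from compound 2 to compound 3 are likewise unreadable. No readable step bears on the change, so no direction can be expected beyond the scatter, and for compound 4 the step that the limit leaves unreadable from compound 2 to compound 4 is expected to be nil on the numbers shown. Compound 4 is estimated at 500000 nM, within 200000 nM to 3000000 nM, most likely reported again only as a limit.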

Compound 4, half-maximal cytotoxic concentration: > 300000 nM
Compound 4: a limit, no number; the forecaster's own chance of this, stated with the estimate: 85%; the middle value does not contradict the limit.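

No step among compound 1, compound 2, compound 3 and compound 4 can be read, as all four sit at one limit: the limit of > 300000 nM in this assay, at which 4 of the 4 values shown sit.

The compounds shown leave open whether the cyclohexylamino, isobutylamino, cyclopentylamino and hexylsulfanyl analogues differ at all in cytotoxicity in this assay.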